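The compounds below may be only part of what the source reports. "The series", "measured", "known", "first", "only" and "open" are said of these compounds alone.

Working notes on the series. Among the measured compounds shown here, in an ADME assay on microsomes from liver (Mus musculus) for metabolic stability, read by LC-MS, using NADPH, tested at 4.6 uM (a higher number here means that the compound lasts longer, a lower number that the compound disappears faster), compound 3 (`O=C(NCCCCc1ccccc1)n1cc(-c2ccccn2)oc1=O`) gives 0.167 h, the lowest number so far, and compound 1 (`COc1cccc(-c2cn(C(=O)NCCCCc3ccccc3)c(=O)o2)c1`) gives 0.5 h. Compound 2 (`COc1cc(-c2cn(C(=O)NCCCCc3ccccc3)c(=O)o2)ccc1F`) reads > 1 h, which is a limit of the assay and not a number.

Compound 4 (`O=C(NCCCCc1ccccc1)n1cc(-c2cccnc2)oc1=O`) has the same atoms as compound 3, joined differently: pyridin-3-yl in place of pyridin-2-yl on an aromatic carbon, next to the ring oxygen (pyridin-3-yl in place of pyridin-2-yl on an aromatic carbon).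

For the measured compounds named here, two measured steps bear on this change, though only indirectly. Putting pyridin-2-yl in place of 3-methoxyphenyl gave a 3.0-fold lower number from compound 1 to compound 3 (0.48 log units; beyond the scatter), and putting it in place of 4-fluoro-3-methoxyphenyl gave an at least 5.9-fold lower number from compound 2 to compound 3 (0.77 log units; beyond the scatter). Both exchange a substituted phenyl group for a pyridinyl group, which is a larger change than the one here. The fluoro step, an at least 2.0-fold higher number from compound 1 to compound 2 (0.30 log units; that floor lies within the scatter), concerns the phenyl compounds only. Going by the values given here, no measured pair shows a shift of the ring nitrogen alone.

Compound 3, at 0.167 h, is therefore the closest guide, and no step beyond the scatter is expected. The expected step is a 1.5-fold higher number from compound 3 to compound 4 (0.18 log units; within the scatter), a slight rise at most. For compound 4 the estimated half-life is 0.25 h, with an expected range from 0.1 h to 0.6 h.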

Compound 4, half-life: > 1 h
Compound 4 ended at the assay's limit; the forecaster's own chance of this, stated with the estimate: 7%; middle value at least 4.0-fold (0.60 log units) from the limit.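

In this assay, among the compounds shown here, pyridin-3-yl in place of pyridin-2-yl on the aromatic carbon next to the ring oxygen gives an at least 5.9-fold higher number from compound 3 to compound 4 (0.77 log units; beyond the scatter) with the same atoms throughout, the first sign that the place of the nitrogen within this group matters on its own, which no earlier pair could show. A pyridinyl group at this position therefore need not shorten the half-life as it did in compound 3: pyridin-3-yl in place of 3-methoxyphenyl gives an at least 2.0-fold higher number from compound 1 to compound 4 (0.30 log units; that floor lies within the scatter) and, with that floor within the scatter, this step does not yet set compound 4 clearly ahead of compound 1. The value of compound 4 is a limit of the assay and not a number, and the step from compound 2, whose value is also a limit, cannot be read: the limit of > 1 h in this assay, at which 2 of the 4 values shown sit.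

Going by these compounds, how compound 2 and compound 4 stand relative to each other stays open, as does the true half-life of each. Also open, on these data alone, is whether pyridin-4-yl, or an amine or a carboxylic acid on the pyridin-3-yl group, would keep the half-life of compound 4 in this assay.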